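The source may report more compounds than this note shows. Statements on the series, on what has been measured and on what is new or still open speak of the compounds shown alone.

Measured compounds:
compound 1, `COc1cc(C2Oc3cc([C@H]4Oc5cc(O)cc(O)c5C(=O)[C@@H]4O)ccc3OC2COC(=O)c2ccc(N)cc2)ccc1O`: 14300 nM
compound 2, `COc1cc(C2Oc3cc([C@H]4Oc5cc(O)cc(O)c5C(=O)[C@@H]4O)ccc3OC2COC(=O)c2ccccc2)ccc1O`: 12700 nM

In a functional assay on liver (Rattus norvegicus, strain Sprague-Dawley) for inhibition, with a stated time of 1 h (a higher number here means a weaker inhibitor, a lower number a stronger inhibitor), compound 1 gives 14300 nM, the highest of the two numbers recorded. Compound 2 gives 12700 nM in this assay; the step of a 1.1-fold lower number from compound 1 to compound 2 (0.05 log units; within the scatter) is within the scatter, so the two values are not distinguished.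

Compound 3, `COc1cc(C2Oc3cc([C@H]4Oc5cc(O)cc(O)c5C(=O)[C@@H]4O)ccc3OC2COC(=O)c2ccc([N+](=O)[O-])cc2)ccc1O`, differs from compound 1 by nitro in place of amino on an aromatic carbon. For the measured compounds named here, the only measured step that touches this position is a 1.1-fold lower number from compound 1 to compound 2 (0.05 log units; within the scatter), where removal of the amino group left the number effectively unchanged. Going by the values given here, no measured step introduces a nitro group, so there is nothing that points to a shift in this assay beyond the scatter in either direction.

Compound 3 is therefore expected to stay close to compound 1, with an estimated 13000 nM in this assay, in the range 5000 nM to 32000 nM. The expected step of a 1.1-fold lower number from compound 1 to compound 3 (0.04 log units; within the scatter) is estimated to lie within the scatter.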

Compound 3, half-maximal inhibitory concentration: 12600 nM
Beside the measured number, compound 3's estimate is 1.0-fold (0.01 log units) above it; measured number inside the range.
By their numbers in this assay, from the lowest: compounds 3, 2 and 1 (each within the scatter of the next).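

In this assay, nitro in place of amino gives a 1.1-fold lower number from compound 1 to compound 3 (0.05 log units; within the scatter), and nitro in place of hydrogen gives a 1.0-fold lower number from compound 2 to compound 3 (0.00 log units; within the scatter). Amino, hydrogen and nitro on this aromatic carbon, para to a large group, therefore cannot be told apart, even though nitro brings more heavy atoms and no hydrogen-bond donor. So far, the position shows no response to the group it carries, whether that group is taken away or replaced with a larger one, and no measurement available here speaks to why the three values coincide.

The compounds shown leave open whether a carboxylic acid or a longer chain in the same place would also fail to separate from these three, and whether the phenyl ring itself can be replaced. On these data alone, all three compounds share the core of compound 1, so changes to that core remain untested.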